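A benzylamine in place of an aryl ether

A few compounds are considered here, and "the series" means these few. Any claim that something is new, unique, unknown or untested is made for them only; others in the source may bear on it.

Compound 1 `Nc1cc(N)c2nc(-c3ccccc3)c(Oc3ccc(Cl)c(Cl)c3)nc2c1` is the starting point. In a functional assay on NCI-H23 cells (Homo sapiens) for inhibition, read by sulforhodamine B assay, with a stated time of 48 h (a higher number here means that more compound is tolerated, a lower number that less compound is tolerated), compound 1 gives only a limit of < 100000 nM, so its true value is not pinned down (the limit of < 100000 nM in this assay, at which 1 of the 3 values shown sits). Two further compounds are known: compound 2 `COc1cc(CNc2nc3cc(N)cc(N)c3nc2-c2ccccc2)cc(OC)c1OC` and compound 3 `CCOC(=O)[C@H](CCC(=O)O)NC(=O)c1ccc(Oc2nc3cc(N)cc(N)c3nc2-c2ccccc2)cc1`. Compound 2 gives 33900 nM in this assay, and compound 3 gives 60300 nM in this assay, both being actual numbers. The untested compound 4 `Nc1cc(N)c2nc(-c3ccccc3)c(NCc3ccc(F)cc3)nc2c1` differs from compound 1 in one place: (4-fluorobenzyl)amino in place of 3,4-dichlorophenoxy on an aromatic carbon. Going by the values given here, no measured pair differing in a single place is available, so the expected step rests on the spread of the three values. The step that the limit leaves unreadable from compound 1 to compound 4 is expected to be small, likely within the scatter. Compound 4 is expected to give 40000 nM in this assay, estimated to lie between 15000 nM and 100000 nM.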

Compound 4, concentration lethal to 50% of the cells: 8910 nM
Estimate against measurement, compound 4: 4.5-fold (0.65 log units) above; measured number below the stated range.
By their numbers in this assay, from the lowest: compound 4; then compounds 2 and 3 (each within the scatter of the next).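

The change from compound 1 to compound 4 gives no readable step, because compound 1 carries only a limit: the limit of < 100000 nM in this assay, at which 1 of the 4 values shown sits.

The compounds shown leave open how large this change truly is, and which part of the (4-fluorobenzyl)amino group would account for any difference.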